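A few compounds are considered here, and "the series" means these few. Any claim that something is new, unique, unknown or untested is made for them only; others in the source may bear on it.

Compound 1 `COc1ccc(C(=O)/C=C/c2cc3ccccc3[nH]c2=O)cc1` and compound 2 `O=C(/C=C/c1cc2ccccc2[nH]c1=O)c1ccc(O)cc1` share one core and differ only at an oxygen on an aromatic ring. In a functional assay on OVCAR-8 cells (Homo sapiens) for cytotoxicity, read by sulforhodamine B assay, with a stated time of 24 h (a higher number here means a weaker inhibitor of growth, a lower number a stronger inhibitor of growth), compound 1 reaches only the limit of > 100000 nM. Among the compounds with values here, compound 2 gives 21100 nM in this assay, the single number among the two values shown. The step of an at least 4.7-fold lower number from compound 1 to compound 2 (0.67 log units; beyond the scatter) is bounded by the limit (the limit of > 100000 nM in this assay, at which 1 of the 2 values shown sits). Compound 3 `O=C(/C=C/c1cc2ccccc2[nH]c1=O)c1ccc(Cl)cc1` carries chloro in place of hydroxy on an aromatic carbon. Within the data shown here, no measured step removes a hydrogen-bond donor, so that step offers only loose guidance; a modest weakening is expected, a 2.1-fold higher number from compound 2 to compound 3 (0.33 log units; beyond the scatter). Compound 3 is therefore estimated at 45000 nM, in a range from 15000 nM to 100000 nM.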

Compound 3, concentration for total growth inhibition: 21200 nM
The estimate for compound 3 lay 2.1-fold (0.33 log units) above the measured number, within the range that was stated.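

Chloro in place of hydroxy, on an aromatic carbon para to a large group, gives a 1.0-fold higher number from compound 2 to compound 3 (0.00 log units; within the scatter) in this assay, so a hydrogen-bond donor at this position is not needed for the number seen with compound 2. Chloro in place of methoxy gives an at least 4.7-fold lower number from compound 1 to compound 3 (0.67 log units; beyond the scatter), which leaves methoxy as the one group of the three that stands apart. The size of that step is bounded by a limit and is not a measured number: the limit of > 100000 nM in this assay, at which 1 of the 3 values shown sits.

The compounds shown leave open whether an amine or a carboxylic acid at this position would read like compound 2 and compound 3 or like compound 1. They also leave open whether a longer chain on the oxygen would read like compound 1.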